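Second 2-cyanoethyl arm on compound 3

This account rests on a few compounds, and the source may have more. Where it says the series, first, only, none or still open, it means among the compounds named here.

In a functional assay on HepG2 cells (Homo sapiens), read by MTT assay, with a stated time of 48 h (on this read-out higher numbers stand for weaker inhibition and lower numbers for stronger inhibition), compound 1 `CCn1c(C(=O)NCCN(C)C)ccc1C(CC)(CC)c1ccc(OCC(O)C(C)(C)C)c(C)c1` gives 870 nM as its value and compound 2 `CCN(CC)CCCNC(=O)c1ccc(C(CC)(CC)c2ccc(OCC(O)C(C)(C)C)c(C)c2)n1CC` gives 1100 nM as its value.

Compound 3 `CCn1c(C(=O)N(C)CCC#N)ccc1C(CC)(CC)c1ccc(OCC(O)C(C)(C)C)c(C)c1` gives > 50000 nM as its reading, which is a limit and not a number, and so stands at the limit of > 50000 nM in this assay, at which 1 of the 3 values shown sits, on the numbers shown.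

Compound 4 `CCn1c(C(=O)N(CCC#N)CCC#N)ccc1C(CC)(CC)c1ccc(OCC(O)C(C)(C)C)c(C)c1` carries cyanomethyl in place of hydrogen on a saturated chain carbon bound to an amide-type nitrogen.

Among the measured compounds shown here, no measured step makes this exact change. The nearest steps alter the same amide substituent: an at least 57-fold higher number from compound 1 to compound 3 (1.75 log units; beyond the scatter) and an at least 45-fold higher number from compound 2 to compound 3 (1.65 log units; beyond the scatter) are both large, while a 1.3-fold higher number from compound 1 to compound 2 (0.10 log units; within the scatter) stays within the scatter.

Compound 4 keeps the 2-cyanoethyl arm of the large step of an at least 45-fold higher number from compound 2 to compound 3 (1.65 log units; beyond the scatter) and has no amine chain of the kind found in the two measured compounds. No step beyond the scatter is therefore expected in this assay for this change.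

The estimated step is a number no higher from compound 3 to compound 4 (the limit leaves the size open) and a reading at the limit is the likeliest outcome.

Compound 4 is estimated at 50000 nM with an expected range of 15000 nM to 150000 nM on this reading.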

Compound 4, half-maximal inhibitory concentration: 42000 nM
The estimate for compound 4 lay 1.2-fold (0.08 log units) above the measured number; low and high end bracket the measured number.
By their numbers in this assay, from the lowest: compounds 1 and 2 (each within the scatter of the next); then compound 4. At a limit, above all of these: compound 3.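

In this assay, the arm on the carbonyl carbon that carries two 2-cyanoethyl groups gives a number for an amide with no amine chain: a 38-fold higher number from compound 2 to compound 4 (1.58 log units; beyond the scatter), and a 48-fold higher number from compound 1 to compound 4 (1.68 log units; beyond the scatter). Compound 3 gives only a limit, not a number: the limit of > 50000 nM in this assay, at which 1 of the 4 values shown sits. The change of methyl to 2-cyanoethyl gives an at least 1.1-fold lower number from compound 3 to compound 4 (0.07 log units; that floor lies within the scatter), so this second arm brings no change that can be told from the scatter.

Still open, as far as these compounds go, is which difference carries the large steps, as compound 3 and compound 4 differ from compound 1 and compound 2 at once in the amine, the nitrile and the amide hydrogen. A plain butyl chain or a 2-hydroxyethyl arm on the amide would begin to separate these.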